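The compounds below may be only part of what the source reports. "The series", "measured", "known", "first", "only" and "open" are said of these compounds alone.

Working notes on the series.

Of the compounds shown here, two have been measured in an assay on HEK293 cells for antagonist activity at transient receptor potential cation channel subfamily V member 3 (Homo sapiens), read by FLIPR and calcium flux; on this read-out lower numbers stand for stronger inhibition and higher numbers for weaker inhibition. Compound 1 `O[C@@]1(c2ccccn2)CC[C@@H](c2ccc(C(F)(F)F)cc2)C1` gives 240 nM in this assay. Compound 2 `O[C@H](c1ccccn1)[C@]1(c2ccc(Cl)c(Cl)c2)CCO1` gives 150 nM in this assay. Compound 2 holds the lower of the two numbers, but its nearest neighbour, compound 1, sits within the usual scatter of it, so the two values cannot be ordered; they are treated as equivalent. Among the measured compounds shown here, no pair of measured compounds differs in a single place, so no step between measured compounds can be read from the numbers.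

The next compound, compound 3 `O[C@H](c1ccccn1)[C@@]1(c2ccc(Cl)c(Cl)c2)CCO1`, is the stereochemical counterpart of compound 2: the two compounds have the same atoms and bonds and differ only in configuration as drawn: 1 of 2 stereo elements differ; a stereocentre at a saturated ring carbon is drawn R in compound 2 and S in compound 3. For the measured compounds named here, the series has no measured pair that separates configuration at a saturated ring carbon, so the size and direction of such a step are not known from the data. Since compound 2 gives 150 nM, the inverted configuration is estimated, with low confidence, to weaken inhibition somewhat. The expected step from compound 2 to compound 3 is a 3.0-fold higher number from compound 2 to compound 3 (0.48 log units; beyond the scatter). Compound 3 is estimated at 450 nM, within a range from 120 nM to 2500 nM in this assay.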

Compound 3, antagonist equilibrium constant: 380 nM
The estimate for compound 3 lay 1.2-fold (0.07 log units) above the measured number; low and high end bracket the measured number.
By their numbers in this assay, from the lowest: compounds 2, 1 and 3 (each within the scatter of the next, the first and the last beyond it).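

Among the compounds shown here, this is the first step that can be read between measured compounds, and it gives configuration at a saturated ring carbon both a size and a direction: in this assay, going from the R to the S drawing at that stereocentre gives a 2.5-fold higher number from compound 2 to compound 3 (0.40 log units; beyond the scatter), a modest weakening of inhibition. The position therefore responds to configuration even with all atoms and bonds unchanged, with the R drawing giving the stronger inhibition of this pair, although this rests on a single pair. The step can be tied to this one stereocentre, because nothing else separates the two compounds: the fact that compounds 2 and 3 differ only in the configuration as drawn.

The other stereo element is drawn alike in compound 2 and compound 3, so this pair says nothing about its configuration or about the two remaining stereoisomers. Also open, from the compounds shown here alone, is whether the same inversion would give a step of like size and direction if an amine or a carboxylic acid stood in place of the hydroxyl group.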